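This account rests on a few compounds, and the source may have more. Where it says the series, first, only, none or still open, it means among the compounds named here.

Measured so far in an assay on HEK293 cells for inhibition of N-acylethanolamine-hydrolyzing acid amidase (Rattus norvegicus), read by LC-MS, with a stated time of 30 min; on this read-out higher numbers stand for weaker inhibition and lower numbers for stronger inhibition:
Compound 1, `O=C(CCCCCc1ccc(O)c(Cl)c1)N1CCOC1=O`, gives > 20000 nM, which is a limit of the assay and not a number.
Compound 2, `O=C(CCCCCc1ccc(O)c(F)c1)N1CCOC1=O`, gives 160 nM.
Compound 3, `O=C(CCCCCc1ccc(Br)cc1)N1CCOC1=O`, gives 8510 nM.

Compound 3 therefore stands highest of the two numbers shown in this assay; its nearest neighbour is compound 2, with a clearly lower number, and the remaining value is a limit rather than a number. Among the measured compounds shown here, the only measured step between compounds that differ in one place is an at least 120-fold lower number from compound 1 to compound 2 (2.09 log units; beyond the scatter). Compound 1 sits at the limit of > 20000 nM in this assay, at which 1 of the 3 values shown sits.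

Compound 4, `O=C(CCCCCc1ccc(O)cc1)N1CCOC1=O`, differs from compound 3 by hydroxy in place of bromo on an aromatic carbon. For the measured compounds named here, no measured step swaps a bromo for a hydroxy, and the step from compound 1 to compound 2 concerns a different group, so it bears on this change only indirectly. What the values do show is that compound 2, which carries a hydroxy, gives a much lower number than compound 3, which carries bromo and no hydroxy. On that basis a drop is expected for compound 4, of about a 17-fold lower number from compound 3 to compound 4 (1.23 log units; beyond the scatter), with wide uncertainty. Compound 4 is estimated at 500 nM, between 60 nM and 4000 nM.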

Compound 4, half-maximal inhibitory concentration: 61 nM
Beside the measured number, compound 4's estimate is 8.2-fold (0.91 log units) above it, and the stated range covers the measured number.
By their numbers in this assay, from the lowest: compound 4; then compound 2; then compound 3. At a limit, above all of these: compound 1.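

Hydroxy in place of bromo on an aromatic carbon, para to a large group, gives a 140-fold lower number from compound 3 to compound 4 (2.14 log units; beyond the scatter) in this assay, which is the first direct measure of this change at this position. The halogen is not required for a low number once the hydroxy is present, since hydrogen in place of fluoro gives a 2.6-fold lower number from compound 2 to compound 4 (0.42 log units; beyond the scatter) and this modest step still lies beyond the scatter. Hydrogen in place of chloro gives an at least 320-fold lower number from compound 1 to compound 4 (2.51 log units; beyond the scatter), but this step rests on a limit of the assay for compound 1 and not on a number: the limit of > 20000 nM in this assay, at which 1 of the 4 values shown sits.

The compounds shown leave open whether an amine or a carboxylic acid at this position could stand in for the hydroxy. They also leave open how a longer chain would fare with the hydroxy kept in place.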